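This account rests on a few compounds, and the source may have more. Where it says the series, first, only, none or still open, it means among the compounds named here.

Of the compounds shown here, two from this study have numbers so far. Compound 1 `CC(C)C(c1ccc(-c2ccc3cccc(F)c3c2)[nH]c1=O)N1CCN/C1=N\C#N` and compound 2 `CC(C)C(O)(C(=O)O)c1ccc(-c2ccc3ccccc3c2)[nH]c1=O` share a core, and both were tested in an assay on CHO cells for displacement of a labelled ligand from prostaglandin E2 receptor EP3 subtype (Homo sapiens), read by radioligand binding; on this read-out lower numbers stand for stronger inhibition and higher numbers for weaker inhibition. In this assay compound 1 gives 23 nM, while compound 2 gives 544 nM. Compound 1 thus stands at the lowest of the two numbers, the stronger binder of the pair, and its distance to compound 2 lies beyond the usual scatter of repeated measurements.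

The next compound follows from compound 1. Compound 3 `Cc1c[nH]c(C(c2ccc(-c3ccc4cccc(F)c4c3)[nH]c2=O)C(C)C)n1` keeps the core and the fluorinated ring system of compound 1, but the group attached to the saturated chain carbon is exchanged: a group of 6 heavy atoms (4 carbon, 2 nitrogen; one five-membered aromatic ring with 2 hetero atoms) in place of a group of 8 heavy atoms (4 carbon, 4 nitrogen; one five-membered non-aromatic ring with 2 hetero atoms), on a saturated chain carbon bound to an aromatic carbon and a saturated chain carbon. Going by the values given here, no step between two measured compounds matches this exchange, so there is no measured precedent to lean on; the only anchor is the value of compound 1.

Because compound 1 sits at 23 nM, compound 3 is expected to stay in a similar region, with a modest move toward a higher number, a step of a 2.6-fold higher number from compound 1 to compound 3 (0.42 log units; beyond the scatter) that may not exceed the scatter. The estimate for compound 3 is 60 nM, with a range from 15 nM to 250 nM.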

Compound 3, inhibition constant: 12 nM
The estimate for compound 3 lay 5.0-fold (0.70 log units) above the measured number; measured number outside the range, below it.
By their numbers in this assay, from the lowest: compounds 3 and 1 (each within the scatter of the next); then compound 2.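

In this assay, placing 4-methyl-1H-imidazol-2-yl on a saturated chain carbon bound to an aromatic carbon and a saturated chain carbon, where compound 1 carries its group of 8 heavy atoms, gives a 1.9-fold lower number from compound 1 to compound 3 (0.28 log units; within the scatter) and so leaves the two compounds indistinguishable on this read-out. For this pair, then, the group at this position can go from a five-membered non-aromatic ring with 1 double bond and 1 triple bond outside aromatic rings to a five-membered aromatic ring with neither, and from 2 hydrogen-bond acceptors to 1, without a change beyond the scatter. No measurement shown here explains why these two different groups read alike.

Going by these compounds alone, a single exchange cannot show which features of the two groups matter, and the methyl group on the imidazole ring has no comparison of its own, since no compound here has the same ring without it. As far as these compounds go, what a plain amine or a phenyl ring would give on this same carbon, with the rest of compound 3 unchanged, also remains open.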